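This account rests on a few compounds, and the source may have more. Where it says the series, first, only, none or still open, it means among the compounds named here.

Compound 1 `Cc1cccc(CSc2cc(Cl)c(C)cc2S(=O)(=O)/N=C(\N)n2nccc2-c2ccccc2)c1` gives 47000 nM in a functional assay on MCF7 cells (Homo sapiens) for cytotoxicity, read by MTT assay, with a stated time of 72 h (on this read-out lower numbers stand for stronger inhibition and higher numbers for weaker inhibition), and stands second highest of the three numbers. Compound 3 `Cc1cc(-c2ccccc2)n(/C(N)=N/S(=O)(=O)c2cc(C)c(Cl)cc2SCc2cccc(C(F)(F)F)c2)n1` sits nearest, at 41000 nM in this assay, within the scatter of compound 1; compound 2 `Cc1cc(-c2ccccc2)n(/C(N)=N/S(=O)(=O)c2cc(C)c(Cl)cc2SCc2cccc3ccccc23)n1` sits furthest, at 170000 nM in this assay, beyond the scatter. Compound 4 `Cc1cc(S(=O)(=O)/N=C(\N)n2nccc2-c2ccccc2)c(SCc2ccccc2)cc1Cl` differs from compound 1 by hydrogen in place of methyl on an aromatic carbon, that is (3-methylbenzyl)sulfanyl to benzylsulfanyl. Going by the values given here, the only measured step on this part of the molecule is a 4.1-fold lower number from compound 2 to compound 3 (0.62 log units; beyond the scatter), which exchanges the whole aryl group rather than a single methyl, so it bears on the present change only loosely. Dropping one methyl is a smaller edit, and compound 4 is expected to move little, a 1.1-fold higher number from compound 1 to compound 4 (0.03 log units; within the scatter). Compound 4 is therefore estimated at 50000 nM, between 20000 nM and 125000 nM.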

Compound 4, half-maximal inhibitory concentration: 20000 nM
Compound 4: middle estimate off by 2.5-fold (0.40 log units), on the high side, and the stated range covers the measured number.
By their numbers in this assay, from the lowest: compound 4; then compounds 3 and 1 (each within the scatter of the next); then compound 2.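

Going from (3-methylbenzyl)sulfanyl to benzylsulfanyl gives a 2.4-fold lower number from compound 1 to compound 4 (0.37 log units; beyond the scatter) in this assay and shows that this aromatic carbon responds to the loss of a single methyl. The earlier step, a 4.1-fold lower number from compound 2 to compound 3 (0.62 log units; beyond the scatter), exchanged a whole aryl group and could not show this. No measurement at hand accounts for the shift.

From the compounds shown here alone, whether a chlorine, methoxy or amine in place of this methyl would lower or raise the number remains open. So does whether the same change would carry over to the core of compound 3.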